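From Hydroxy to Dimethoxy: An Expected Loss of Inhibition

The source may hold more compounds than are shown below. What is called first, only, known or untested is meant among the compounds shown, and "the series" means these compounds.

In a functional assay on MCF7 cells (Homo sapiens) for inhibition, read by MTT assay, with a stated time of 48 h (on this read-out higher numbers stand for weaker inhibition and lower numbers for stronger inhibition), compound 2 (`Oc1cccc(C(c2c[nH]c3ccc(Br)cc23)c2c[nH]c3ccc(Br)cc23)c1`) gives 2800 nM and compound 1 (`Brc1ccc2[nH]cc(C(c3ccccc3)c3c[nH]c4ccc(Br)cc34)c2c1`) gives 5500 nM, so the two share the low end of the numbers (a 2.0-fold lower number from compound 1 to compound 2 (0.29 log units; within the scatter)). Compound 3 (`COc1cccc(C(c2c[nH]c3ccc(Br)cc23)c2c[nH]c3ccc(Br)cc23)c1OC`) gives 89000 nM and stands far from both. Compound 4 (`COc1ccc(C(c2c[nH]c3ccc(Br)cc23)c2c[nH]c3ccc(Br)cc23)cc1OC`) differs from compound 2 by 3,4-dimethoxyphenyl in place of 3-hydroxyphenyl on a saturated chain carbon bound to two aromatic carbons and so has 3,4-dimethoxyphenyl in place of 3-hydroxyphenyl on a saturated chain carbon bound to two aromatic carbons. The closest measured change is 2,3-dimethoxyphenyl (a 32-fold higher number from compound 2 to compound 3 (1.50 log units; beyond the scatter)), and the change from phenyl to 2,3-dimethoxyphenyl points the same way (a 16-fold higher number from compound 1 to compound 3 (1.21 log units; beyond the scatter)). The methoxy pattern of compound 4 is not the same, so a smaller rise is expected in this assay (a 7.1-fold higher number from compound 2 to compound 4 (0.85 log units; beyond the scatter)). The estimate for compound 4 is 20000 nM (expected range 4000 nM to 90000 nM).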

Compound 4, half-maximal inhibitory concentration: 7800 nM
Estimate against measurement, compound 4: 2.6-fold (0.41 log units) above; measured number inside the range.
By their numbers in this assay, from the lowest: compounds 2, 1 and 4 (each within the scatter of the next, the first and the last beyond it); then compound 3.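

In this assay, the large loss seen earlier does not belong to every dimethoxyphenyl group at this saturated chain carbon: 3,4-dimethoxyphenyl in place of 2,3-dimethoxyphenyl gives an 11-fold lower number from compound 3 to compound 4 (1.06 log units; beyond the scatter). Replacing 3-hydroxyphenyl costs far less, with a 2.8-fold higher number from compound 2 to compound 4 (0.44 log units; beyond the scatter), and the comparison with phenyl separates nothing (a 1.4-fold higher number from compound 1 to compound 4 (0.15 log units; within the scatter)). Nothing available explains why the two methoxy patterns differ.

Still open, on these data alone, is how a single methoxy group would behave on this ring. Also open, as far as these compounds go, is whether an amine or a carboxylic acid would be tolerated there.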